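The compounds below may be only part of what the source reports. "The series", "measured", "known", "first", "only" and "open" are said of these compounds alone.

Measured so far:
compound 1 `Cc1cccc(COc2ccc(-c3nn(CCC#N)c(=O)o3)cc2)c1` — 8 nM
compound 2 `Cc1ccc(COc2ccc(-c3nn(CCC#N)c(=O)o3)cc2)cc1` — 15 nM
compound 3 `Cc1cccc(COc2ccc(-c3nn(CCC#N)c(=S)o3)cc2)c1` — 66 nM

In an assay for inhibition of Amine oxidase [flavin-containing] B (Rattus norvegicus) (on this read-out higher numbers stand for weaker inhibition and lower numbers for stronger inhibition), compound 1 gives 8 nM, and compound 2 gives 15 nM. These two differ in a single place: 4-methylphenyl in place of 3-methylphenyl on a saturated chain carbon bound to an oxygen on an aromatic ring. That change produced a 1.9-fold higher number from compound 1 to compound 2 (0.27 log units; within the scatter), so the two values cannot be told apart with confidence. Compound 3 gives 66 nM in this assay, a weaker result than either of the first two; how its core differs from the core of compound 1 is not broken down here. Compound 4 `Cc1ccc(COc2ccc(-c3nn(CCC#N)c(=S)o3)cc2)cc1` has not yet been measured. It stands to compound 3 exactly as compound 2 stands to compound 1: 4-methylphenyl in place of 3-methylphenyl on a saturated chain carbon bound to an oxygen on an aromatic ring. Because the same change gave a 1.9-fold higher number from compound 1 to compound 2 (0.27 log units; within the scatter), the step from compound 3 to compound 4 is expected to be of a similar small size, a 1.8-fold higher number from compound 3 to compound 4 (0.26 log units; within the scatter). On that basis compound 4 is estimated at 120 nM in this assay, most likely somewhere between 45 nM and 350 nM.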

Compound 4, half-maximal inhibitory concentration: 400 nM
Estimate against measurement, compound 4: 3.3-fold (0.52 log units) below, and the stated range ends below it.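

In this assay, putting 4-methylphenyl in place of 3-methylphenyl on the core of compound 3 gives a 6.1-fold higher number from compound 3 to compound 4 (0.78 log units; beyond the scatter), a clear loss of inhibition for a change that keeps the same atoms and only joins them differently. Set beside the earlier step, this shows that the change does not carry over at a constant size from one core to the other: the same change on two cores in this assay, a 1.9-fold higher number (0.27 log units; within the scatter) from compound 1 to compound 2 and a 6.1-fold higher number (0.78 log units; beyond the scatter) from compound 3 to compound 4, 3.2-fold (0.51 log units) apart, beyond the scatter of two such steps. These two pairs do not show why the size differs, and they cannot say how large the step would be on any third core, so the size of this step on one core is a poor guide to its size on another.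

The compounds shown leave open how a plain phenyl group, with no methyl at all, would compare on each of the two cores. They also leave open whether the same gap between the two steps would remain with a longer chain in place of the one that carries the nitrile.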